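Removing the Methyl Next to the Thiazole Core

The source may report more compounds than this note shows. Statements on the series, on what has been measured and on what is new or still open speak of the compounds shown alone.

Measured so far:
- compound 1, `CC(c1nccs1)C(C#N)(C#N)CCC(F)=C(F)F`: > 120000 nM
- compound 2, `CC(c1nccs1)C(C#N)C#N`: > 120000 nM

In a functional assay on HepG2 cells (Homo sapiens) for cytotoxicity, read by MTT assay, with a stated time of 48 h (a higher number here means a weaker inhibitor, a lower number a stronger inhibitor), compound 2 gives > 120000 nM. That figure is a limit of the assay rather than a measured number; compound 2 showed no effect up to the highest concentration tested. Compound 1 sits at the same kind of limit in this assay, with > 120000 nM. Across the two values shown, there is therefore no number at all, only the limit described in the limit of > 120000 nM in this assay, at which 2 of the 2 values shown sit.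

Compound 3, `N#CC(C#N)Cc1nccs1`, differs from compound 2 in one place: hydrogen in place of methyl on a saturated chain carbon bound to an aromatic carbon and a saturated chain carbon. Going by the values given here, no comparable step between two measured compounds exists here, so no measured size can be carried over.

Given that compound 2 shows only a limit in this assay, the expected step from compound 2 to compound 3 is a step that the limit leaves unreadable from compound 2 to compound 3, essentially none beyond the scatter. Compound 3 is therefore estimated at 150000 nM in this assay, within 60000 nM to 500000 nM, most likely reported again as a limit.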

Compound 3, half-maximal inhibitory concentration: > 120000 nM
Compound 3 gave a limit, no number; the forecaster's own chance of this, stated with the estimate: 85%; the middle value does not contradict the limit.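

Compound 3 gives > 120000 nM in this assay, which is a limit and not a number. Compound 2 also stands at a limit, so no step can be read between compound 2 and compound 3. The compounds shown leave open whether hydrogen in place of methyl changes cytotoxicity at all, because every value is the same limit: the limit of > 120000 nM in this assay, at which 3 of the 3 values shown sit.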